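From 1H-indol-4-yl to quinolin-3-yl on a shared core

This account rests on a few compounds, and the source may have more. Where it says the series, first, only, none or still open, it means among the compounds named here.

Of the compounds shown here, three with one shared core have been measured so far in a functional assay on K562 cells (Homo sapiens) for inhibition, read by trypan blue exclusion, with a stated time of 72 h; on this read-out lower numbers stand for stronger inhibition and higher numbers for weaker inhibition. Compound 1 `COc1ccc(Nc2ncc3cc(S(=O)(=O)c4ccc(Cl)cc4)c(=O)n(C)c3n2)cc1` gives 15000 nM and compound 2 `Cn1c(=O)c(S(=O)(=O)c2ccc(Cl)cc2)cc2cnc(Nc3ccc4[nH]ccc4c3)nc21` gives 100 nM while compound 3 `Cn1c(=O)c(S(=O)(=O)c2ccc(Cl)cc2)cc2cnc(Nc3cccc4[nH]ccc34)nc21` gives 5000 nM as the second highest number of the three. Compound 4 `Cn1c(=O)c(S(=O)(=O)c2ccc(Cl)cc2)cc2cnc(Nc3cnc4ccccc4c3)nc21` has not been measured. It carries quinolin-3-yl in place of 1H-indol-4-yl on a nitrogen on an aromatic ring. Earlier changes at this same place bear on it. Two were large (a 150-fold lower number from compound 1 to compound 2 (2.18 log units; beyond the scatter)) and (a 50-fold higher number from compound 2 to compound 3 (1.70 log units; beyond the scatter)), and one was modest (a 3.0-fold lower number from compound 1 to compound 3 (0.48 log units; beyond the scatter)). Going by the values given here, this place can clearly move the number a long way, but none of the measured compounds carries quinolin-3-yl, so the direction remains uncertain. Most of the measured spread lies below compound 3, so a modest step towards a lower number is expected in this assay (a 3.3-fold lower number from compound 3 to compound 4 (0.52 log units; beyond the scatter)). Compound 4 is estimated at 1500 nM (expected range 200 nM to 10000 nM).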

Compound 4, half-maximal inhibitory concentration: 15000 nM
For compound 4 the middle estimate is 10-fold (1.00 log units) below the measured one; measured number outside the range, above it.
By their numbers in this assay, from the lowest: compound 2; then compound 3; then compounds 1 and 4 (each within the scatter of the next).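

In this assay quinolin-3-yl, replacing 1H-indol-4-yl, gives a 3.0-fold higher number from compound 3 to compound 4 (0.48 log units; beyond the scatter) and so moves the number the opposite way from the modest gain that was expected. Set against 1H-indol-5-yl, the same group gives a 150-fold higher number from compound 2 to compound 4 (2.18 log units; beyond the scatter) and thus confirms that having two aromatic rings at this place does not by itself secure a low number, since among the three such groups only compound 2 reaches one. Set against 4-methoxyphenyl, which has a single ring, quinolin-3-yl gives no change at the digits printed from compound 1 to compound 4 (within the scatter) so the second ring brings no measurable benefit in this case.

Going by these compounds, this step swaps a hydrogen-bond donor for an acceptor and a five-membered ring for a six-membered one at the same time, so the two changes cannot be separated, and how 1H-indazol-5-yl or a phenyl ring carrying a carboxylic acid would fare remains open. No supporting measurement is available to explain these differences.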